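Aromatic amine in place of a basic chain

This account rests on a few compounds, and the source may have more. Where it says the series, first, only, none or still open, it means among the compounds named here.

compound 1, `CNCCCNc1c(C(=O)NCc2ccc(F)cc2)nc(Br)c2cccnc12`: > 10000 nM
compound 2, `O=C(NCCCNc1c(C(=O)NCc2ccc(F)cc2)nc(Br)c2cccnc12)c1ccccc1`: 2000 nM
compound 3, `O=CNCCCCCCNc1nc(C(=O)NCc2ccc(F)cc2)c(O)c2ncccc12`: 19000 nM

Of the compounds shown here, three sharing a core have been tested in a functional assay on MCF7 cells (Homo sapiens) for cytotoxicity, read by MTT assay, with a stated time of 72 h; on this read-out lower numbers stand for stronger inhibition and higher numbers for weaker inhibition. For compound 1 the reading of > 10000 nM is a limit of the assay, not a number. Compound 2 gives 2000 nM in this assay, and compound 3 gives 19000 nM. Among the compounds with values here, only one step between compounds differing in one place is known: an at least 5.0-fold lower number from compound 1 to compound 2 (0.69 log units; beyond the scatter), where a benzoyl in place of methyl on the amine nitrogen brought an aromatic ring into the side group.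

Compound 4, `Nc1cccc(Nc2c(C(=O)NCc3ccc(F)cc3)nc(Br)c3cccnc23)c1`, differs from compound 1 by 3-aminophenyl in place of 3-(methylamino)propyl on a nitrogen on an aromatic ring. This change also introduces an aromatic ring into the side group, though it replaces the chain outright rather than capping it. Because compound 1 sits at the limit of > 10000 nM in this assay, at which 1 of the 3 values shown sits, its step to compound 4 can only be judged from one side. The step from compound 1 to compound 2 suggests a lower number is plausible, but the change here is of a different kind, so the expectation is wide. The estimated step is an at least 1.2-fold lower number from compound 1 to compound 4 (0.09 log units; that floor lies within the scatter). Compound 4 is therefore expected to give 8000 nM, within 2000 nM to 30000 nM.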

Compound 4, half-maximal inhibitory concentration: 8000 nM
The estimate for compound 4 equals the measured number at the digits printed; low and high end bracket the measured number.
By their numbers in this assay, from the lowest: compound 2; then compound 4; then compound 3.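

With 3-aminophenyl in place of 3-(methylamino)propyl on a nitrogen on an aromatic ring, the side group holds no chain, yet this assay still returns a number for compound 4. Within the data shown here, a capped chain as in compound 2 is therefore not the only side group at this position that gives a reading within the range of the assay, and the change gives an at least 1.2-fold lower number from compound 1 to compound 4 (0.09 log units; that floor lies within the scatter). The true size of this step stays unsettled because compound 1 gives only a limit: the limit of > 10000 nM in this assay, at which 1 of the 4 values shown sits.

Still open, going by these compounds, is whether a phenyl group with no amine, or one with a carboxylic acid in place of that amine, would read differently from compound 4. Also open, on these data alone, is whether a benzoyl on the amine of compound 4 would lower the number, as it did on the chain of compound 2.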